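A few compounds are considered here, and "the series" means these few. Any claim that something is new, unique, unknown or untested is made for them only; others in the source may bear on it.

Compound 1 `Cc1cc(NC(=O)Cn2nnc(-c3cccc(Cl)c3)n2)n(C2CCCCC2)n1` gives 89% in an assay on HEK293 cells for activation of Kir3.1/Kir3.2 (Homo sapiens), read by thallium flux; a higher number here means a larger maximal response, a lower number a smaller maximal response. Compound 2 `Cc1cc(NC(=O)Cn2nnc(-c3cc(Cl)cc(Cl)c3)n2)n(C2CCCCC2)n1` gives 82% in this assay. Compound 3 `Cc1cc(NC(=O)Cn2nnc(-c3cccc(F)n3)n2)n(C2CCCCC2)n1` gives > 83% in this assay, and that number is a limit of the assay, not a measured value.

Because (the limit of > 83% in this assay, at which 1 of the 3 values shown sits), compound 3 has no exact position on the scale; it is only known to lie beyond that line. The step that the limit leaves unreadable from compound 1 to compound 3 is therefore unreadable, and the step of a number at least 1 percentage points higher from compound 2 to compound 3 (that floor lies within the scatter) gives only a floor. Among the carbon-only rings, the step of a number 7 percentage points lower from compound 1 to compound 2 (within the scatter) shows that adding a chloro changes little.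

Compound 4 `Cc1cccc(-c2nnn(CC(=O)Nc3cc(C)nn3C3CCCCC3)n2)c1` differs from compound 3 by 3-methylphenyl in place of 6-fluoropyridin-2-yl on an aromatic carbon. Among the measured compounds shown here, no measured step bears directly on this exchange. Compound 4 carries a carbon-only ring like compound 1, whose 89% sits close to the other carbon-only ring of compound 2 with its 82%. The step that the limit leaves unreadable from compound 3 to compound 4 is expected to stay within the scatter, with a fair chance that compound 4 again reaches the limit. Compound 4 is estimated at 87%, between 76% and 98%.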

Compound 4, largest response reached (Emax), in percent of the reference or control that the assay uses: 93%
The estimate for compound 4 lay 6 percentage points below the measured number; low and high end bracket the measured number.
By their numbers in this assay, from the lowest: compounds 2, 1 and 4 (each within the scatter of the next, the first and the last beyond it).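

Exchanging chloro for methyl on the carbon-only ring gives a number 4 percentage points higher from compound 1 to compound 4 (within the scatter) and shows that, in these compounds, a halogen on that ring is not needed for a large maximal response. Exchanging 3,5-dichlorophenyl for 3-methylphenyl on the same aromatic carbon gives a number 11 percentage points higher from compound 2 to compound 4 (beyond the scatter) and is the first readable step among these compounds to pass beyond the scatter, though only modestly. Compound 3 gives > 83%, which is a limit and not a measured number, so its step to compound 4 cannot be read: the limit of > 83% in this assay, at which 1 of the 4 values shown sits.

From the compounds shown here alone, how an amine or a carboxylic acid in place of the methyl of 3-methylphenyl would change the maximal response stays open. The effect of a longer chain, such as ethyl, on that ring is open as well.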